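This account rests on a few compounds, and the source may have more. Where it says the series, first, only, none or still open, it means among the compounds named here.

In a functional assay on PANC-1 cells (Homo sapiens) for antiproliferative activity, read by CCK-8 assay, with a stated time of 72 h (on this read-out lower numbers stand for stronger inhibition and higher numbers for weaker inhibition), compound 3 `Cc1cc(Nc2cc(N3CCN(C)CC3)nc(Nc3cccc(Cl)c3)n2)n[nH]1` gives 351 nM, and compound 2 `Cc1cc(Nc2cc(N3CCN(C)CC3)nc(Nc3ccc(Cl)cc3)n2)n[nH]1` gives 455 nM, so the two stand level within the scatter, a 1.3-fold lower number from compound 2 to compound 3 (0.11 log units; within the scatter). Compound 1 `Cc1cc(Nc2cc(N3CCN(C)CC3)nc(Nc3ccc(S(N)(=O)=O)cc3)n2)n[nH]1` sits far off at 8760 nM, a 25-fold lower number from compound 1 to compound 3 (1.40 log units; beyond the scatter). Compound 4 `Cc1cc(Nc2cc(N3CCN(C)CC3)nc(Nc3ccc(C#N)cc3)n2)n[nH]1` has 4-cyanophenyl in place of 3-chlorophenyl on a nitrogen on an aromatic ring. Going by the values given here, no measured step swaps in a nitrile. Moving the chloro group changed little, a 1.3-fold lower number from compound 2 to compound 3 (0.11 log units; within the scatter), whereas chloro in place of sulfamoyl was a large step, a 19-fold lower number from compound 1 to compound 2 (1.28 log units; beyond the scatter). A moderate move toward a higher number is therefore expected, possibly not beyond the scatter. The expected step is a 2.3-fold higher number from compound 3 to compound 4 (0.36 log units; beyond the scatter). Compound 4 is estimated at 800 nM, with an expected range from 300 nM to 2500 nM.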

Compound 4, half-maximal inhibitory concentration: 435 nM
The estimate for compound 4 lay 1.8-fold (0.26 log units) above the measured number, and the stated range covers the measured number.
By their numbers in this assay, from the lowest: compounds 3, 4 and 2 (each within the scatter of the next); then compound 1.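

In this assay cyano in place of chloro on an aromatic carbon leaves the number within the scatter (a 1.0-fold lower number from compound 2 to compound 4 (0.02 log units; within the scatter)), and 4-cyanophenyl stands level with 3-chlorophenyl on this nitrogen (a 1.2-fold higher number from compound 3 to compound 4 (0.09 log units; within the scatter)). Compounds 2, 3 and 4 thus stand level with three different aryl groups, while cyano in place of sulfamoyl is a large step (a 20-fold lower number from compound 1 to compound 4 (1.30 log units; beyond the scatter)), so a second replacement for sulfamoyl also leaves compound 1 far apart. No measurement given here explains these results.

The compounds shown leave open whether an amine or a carboxylic acid on this phenyl ring would stay level with compounds 2, 3 and 4 or fall closer to compound 1. They also leave open whether 3-cyanophenyl would stand level with 4-cyanophenyl.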